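The source may report more compounds than this note shows. Statements on the series, on what has been measured and on what is new or still open speak of the compounds shown alone.

Within the data shown here, compound 2 `O=C(NCCCNc1nc(Nc2ccc(-n3cncn3)cc2)ncc1C1CC1)C1CCC1` has the lower of the two numbers so far in an assay on RAW264.7 cells for inhibition of serine/threonine-protein kinase TBK1 (Mus musculus), read by ELISA, with stated times of 30 min and 6 h; on this read-out higher numbers stand for weaker inhibition and lower numbers for stronger inhibition; the nearest is compound 1 `CN(C)Cc1ccc(Nc2ncc(C3CC3)c(NCCCNC(=O)C3CCC3)n2)cc1`, whose number is higher by a 3.7-fold lower number from compound 1 to compound 2 (0.56 log units; beyond the scatter). In this assay compound 2 gives 150 nM and compound 1 gives 550 nM.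

Compound 3 `CN1CCC(c2ccc(Nc3ncc(C4CC4)c(NCCCNC(=O)C4CCC4)n3)cc2)CC1` differs from compound 2 in one place: 1-methylpiperidin-4-yl in place of 1H-1,2,4-triazol-1-yl on an aromatic carbon. Among the measured compounds shown here, the only measured step touching this position is the one from compound 1 to compound 2, where a (dimethylamino)methyl group was exchanged for the 1H-1,2,4-triazol-1-yl and the number fell by a 3.7-fold lower number from compound 1 to compound 2 (0.56 log units; beyond the scatter), a modest change. For the measured compounds named here, no measured pair tests the 1-methylpiperidin-4-yl group itself. The two values together show that this position matters, but only modestly, and the new group resembles neither of the two already compared. Compound 3 is therefore expected to land near compound 2, with a slight lean toward a higher number, giving an expected step of a 2.0-fold higher number from compound 2 to compound 3 (0.30 log units; within the scatter). The estimate for compound 3 in this assay is 300 nM, with a likely range from 100 nM to 900 nM.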

Compound 3, half-maximal inhibitory concentration: 660 nM
Compound 3: the middle estimate sits 2.2-fold (0.34 log units) below what was measured; low and high end bracket the measured number.
By their numbers in this assay, from the lowest: compound 2; then compounds 1 and 3 (each within the scatter of the next).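

In this assay the exchange of the 1H-1,2,4-triazol-1-yl for the larger 1-methylpiperidin-4-yl gives a 4.4-fold higher number from compound 2 to compound 3 (0.64 log units; beyond the scatter) and removes the advantage that compound 2 held over compound 1. Set against the (dimethylamino)methyl group, the same new group gives a 1.2-fold higher number from compound 1 to compound 3 (0.08 log units; within the scatter) and leaves compound 1 and compound 3 indistinguishable on this read-out, even though one group is an open chain and the other a six-membered non-aromatic ring. So this position on the aromatic ring does not respond to every exchange: among these three compounds only compound 2 stands apart, with its steps to both others beyond the scatter, and the two groups that carry an amine nitrogen sit together.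

Nothing measured alongside these numbers explains why the triazole-bearing compound 2 stands apart. The compounds shown also leave open whether an amine nitrogen goes with the higher numbers or the five-membered aromatic ring with the lower one, which a morpholine, a phenyl group or an imidazole at the same position could help to separate.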